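A few compounds are considered here, and "the series" means these few. Any claim that something is new, unique, unknown or untested is made for them only; others in the source may bear on it.

Compound 1, `CCCOC(=O)C1=C(C)NC(=O)NC1c1ccsc1`, gives 6% in an assay on membranes from HeLa cells for displacement of a labelled ligand from adenosine receptor A3 (Homo sapiens), read by scintillation counting, with a stated time of 180 min, tested at 1 uM; a higher number here means more inhibition at the concentration tested (going by the name of the read-out), a lower number less inhibition.
Compound 2, `CC1=C(C(=O)C2CC2)C(c2ccsc2)NC(=O)N1`, gives 1% in this assay.
Compound 3, `CC1=C(C(=O)NC(C)C)C(c2cccs2)NC(=O)N1`, gives 1% in this assay.

Compound 3 stands level with compound 2 at the digits shown, and the two together hold the lowest of the three numbers; the gap from compound 3 to compound 1 lies within the scatter, so the three measured values are not separated.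

Within the data shown here, the only measured step, a number 5 percentage points lower from compound 1 to compound 2 (within the scatter), concerns the group on the carbonyl carbon and leaves the ring on the saturated ring carbon untouched, so it does not bear directly on the move to compound 4. Compound 4, `CC1=C(C(=O)NC(C)C)C(c2ccsc2)NC(=O)N1`, differs from compound 3 as follows: thiophen-3-yl in place of thiophen-2-yl on a saturated ring carbon. Among the measured compounds shown here, compound 2 already carries thiophen-3-yl but also differs from compound 3 on the carbonyl carbon, so no single step connects them; their two values simply sit together at the low end. With all three measured numbers within the scatter of one another, the ring change is expected to give a step of a number 1 percentage points higher from compound 3 to compound 4 (within the scatter) that stays within the scatter. Compound 4 is therefore estimated at 2%, with a range from -8% to 12% in this assay.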

Compound 4, a percentage reported as inhibition, at one concentration (the size of the read-out at that concentration, not a potency): 1%
Compound 4: the middle estimate sits 1 percentage points above what was measured; low and high end bracket the measured number.
By their numbers in this assay, from the lowest: compounds 2, 3, 4 and 1 (each within the scatter of the next).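

In this assay, among these compounds, moving the sulfur's place in the ring, with thiophen-3-yl in place of thiophen-2-yl on the saturated ring carbon, gives no change at the digits printed from compound 3 to compound 4 (within the scatter) and so adds a direct comparison at this position that the earlier compounds lacked. With thiophen-3-yl held fixed, isopropylamino in place of cyclopropyl on the carbonyl carbon gives no change at the digits printed from compound 2 to compound 4 (within the scatter), and isopropylamino in place of propoxy gives a number 5 percentage points lower from compound 1 to compound 4 (within the scatter), so the amide can now be set against both the ketone and the ester. Neither the ring change nor either carbonyl change separates the compounds in this assay, and all of these readings remain close together at the low end.

No supporting data account for these readings. Going by these compounds, whether a phenyl ring at this position, or an amine or a carboxylic acid on the side chain at the carbonyl carbon, would lift the number beyond the scatter remains open.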